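Carbamoyl chloro-for-methyl swap on a benzyloxy analogue

The source may hold more compounds than are shown below. What is called first, only, known or untested is meant among the compounds shown, and "the series" means these compounds.

Compound 1 `Cc1cc(C)cc(NC(=O)NCCNS(=O)(=O)c2ccc(-c3ccccc3Oc3ccc([N+](=O)[O-])c([N+](=O)[O-])c3)s2)c1` is the reference point of this small set. In a functional assay on RS4-11 cells (Homo sapiens) for inhibition, read by CCK-8 assay, with a stated time of 48 h (on this read-out higher numbers stand for weaker inhibition and lower numbers for stronger inhibition), compound 1 gives 3600 nM. Compound 2 `O=C(NCCNS(=O)(=O)c1ccc(-c2ccccc2Oc2ccc([N+](=O)[O-])c([N+](=O)[O-])c2)s1)Nc1cc(Cl)cc(Cl)c1` carries the change 3,5-dichlorophenyl in place of 3,5-dimethylphenyl on an amide-type nitrogen and in this assay compound 2 gives 2100 nM, so that a 1.7-fold lower number from compound 1 to compound 2 (0.23 log units; within the scatter). Compound 3 `Cc1cc(C)cc(NC(=O)NCCNS(=O)(=O)c2ccc(-c3ccccc3OCc3ccccc3)s2)c1` keeps the amide side of compound 1 but differs in the core by benzyl in place of 3,4-dinitrophenyl on an oxygen on an aromatic ring. In this assay compound 3 gives > 50000 nM, which is a limit of the assay and not a number. Accordingly an at least 13-fold higher number from compound 1 to compound 3 (1.14 log units; beyond the scatter), and the evidence for compound 3 is the limit of > 50000 nM in this assay, at which 1 of the 3 values shown sits. Compound 4 `O=C(NCCNS(=O)(=O)c1ccc(-c2ccccc2OCc2ccccc2)s1)Nc1cc(Cl)cc(Cl)c1` has not been measured. It is related to compound 3 by 3,5-dichlorophenyl in place of 3,5-dimethylphenyl on an amide-type nitrogen, the same change that was made from compound 1 to compound 2, at the same place on an amide-type nitrogen. The step is expected to be small, a step that the limit leaves unreadable from compound 3 to compound 4, and this rests on a 1.7-fold lower number from compound 1 to compound 2 (0.23 log units; within the scatter). It rests also on the fact that compound 3 gives > 50000 nM, which is a limit of the assay. Compound 4 is therefore estimated at 60000 nM in this assay, most probably again reported only as a limit.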

Compound 4, half-maximal inhibitory concentration: > 20000 nM
Compound 4: no number, only a limit; the forecaster's own chance of this, stated with the estimate: 75%; the middle value does not contradict the limit.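

Whether 3,5-dichlorophenyl in place of 3,5-dimethylphenyl on an amide-type nitrogen carries over to the benzyl ether core cannot be judged: compound 3 and compound 4 both stand only at limits of the assay, and the step between them cannot be read. In this assay the other change, benzyl in place of 3,4-dinitrophenyl on an oxygen on an aromatic ring, gives an at least 9.5-fold higher number from compound 2 to compound 4 (0.97 log units; beyond the scatter), and it points the same way with either amide side: the same change on two cores in this assay, an at least 13-fold higher number (1.14 log units; beyond the scatter) from compound 1 to compound 3 and an at least 9.5-fold higher number (0.97 log units; beyond the scatter) from compound 2 to compound 4; the limit leaves it open whether they differ. This shows that the weaker inhibition with benzyl holds in both pairs shown, but it does not show that the size of the step is the same in each pair, nor how the chloro-for-methyl swap behaves on the benzyl ether core.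

The compounds shown leave open whether a phenyl carrying a single nitro group, or an amine in place of the nitro groups, would side with compound 1 and compound 2 or with compound 3 and compound 4. They also leave open what a longer chain in the linker would do.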